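This account rests on a few compounds, and the source may have more. Where it says the series, first, only, none or still open, it means among the compounds named here.

Measured compounds in an assay for inhibition of serine/threonine-protein kinase Sgk1 (Homo sapiens), with stated times of 30 min and 60 min, in the presence of a further agent that is not named here; on this read-out lower numbers stand for stronger inhibition and higher numbers for weaker inhibition:
Compound 1, `CN1CCC(NC(=O)c2cc(-c3ccc(NS(=O)(=O)c4cccc(Cl)c4Cl)cc3)nc3[nH]ncc23)C1`. In this assay compound 1 gives < 1 nM, a limit of the assay and not a number.
Compound 2, `CCN1CCC(CNC(=O)c2cc(-c3ccc(NS(=O)(=O)c4cccc(Cl)c4Cl)cc3)nc3[nH]ncc23)C1`. In this assay compound 2 gives < 1 nM, again a limit.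
Compound 3, `Cc1n[nH]c2nc(-c3ccc(NS(=O)(=O)c4cc(Cl)ccc4F)cc3)nc(OCC(CO)CO)c12`. In this assay compound 3 gives 1 nM.

Going by the values given here, compound 3 thus carries the only number in the set; the other two values sit at the limit of < 1 nM in this assay, at which 2 of the 3 values shown sit. Among the compounds with values here, the single measured step, a step that the two limits leave unreadable from compound 1 to compound 2, concerns the amide-type nitrogen and is left unreadable by those limits, so it gives no guide. Compound 4, `Cc1n[nH]c2nc(-c3ccc(NS(=O)(=O)c4cc(Cl)ccc4F)cc3)nc(OCC3CN(C(C)C)C3)c12`, differs from compound 3 by 1-isopropylazetidin-3-yl in place of 2-hydroxy-1-(hydroxymethyl)ethyl on a saturated chain carbon bound to an oxygen on an aromatic ring. Within the data shown here, no measured step touches this part of the shared core, so no direction can be derived. In this assay a step of no change at the digits printed from compound 3 to compound 4 (within the scatter) is expected, nothing beyond the scatter. Compound 4 is therefore estimated at 1 nM, with a range of 0.3 nM to 3 nM.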

Compound 4, half-maximal inhibitory concentration: 1 nM
Beside the measured number, compound 4's estimate shows no gap at the digits printed; the range from low to high includes it.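

Exchanging 2-hydroxy-1-(hydroxymethyl)ethyl for 1-isopropylazetidin-3-yl gives no change at the digits printed from compound 3 to compound 4 (within the scatter) in this assay. Going by these compounds alone, this is the first readable step, since the step between the two amides cannot be read. At this place, on a saturated chain carbon bound to an oxygen on an aromatic ring, the value therefore holds with 0 hydrogen-bond donors in the entering group and a four-membered ring in place of an open chain.

Going by these compounds, whether a carboxylic acid or a primary amine on this chain would hold the value stays open. The values also stand close to where the read-out ends: the limit of < 1 nM in this assay, at which 2 of the 4 values shown sit.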